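Fluoro in place of hydrogen on the terminal phenyl

A few compounds are considered here, and "the series" means these few. Any claim that something is new, unique, unknown or untested is made for them only; others in the source may bear on it.

Compound 1 `CC(C)(C)c1ccc(NC(=O)Nc2cccc(CNc3ncnc4ccccc34)c2)cc1`: 7470 nM
Compound 2 `O=C(Nc1cccc(CNc2ncnc3ccccc23)c1)Nc1ccccc1F`: 33400 nM
Compound 3 `COc1cc2ncnc(NCc3cccc(NC(=O)Nc4ccccc4)c3)c2cc1OC`: 10000 nM

In a functional assay on MGC-803 cells (Homo sapiens) for antiproliferative activity, read by MTT assay (a lower number here means a stronger inhibitor, a higher number a weaker inhibitor), compound 3 stands second highest of the three numbers, within the scatter of compound 1 and beyond the scatter below compound 2. Compound 4 `COc1cc2ncnc(NCc3cccc(NC(=O)Nc4ccccc4F)c3)c2cc1OC` differs from compound 3 by fluoro in place of hydrogen on an aromatic carbon, ortho to a large group on the phenylcarbamoyl end. Among the measured compounds shown here, the only measured step that bears on it is a 4.5-fold higher number from compound 1 to compound 2 (0.65 log units; beyond the scatter), which also ends in a 2-fluorophenyl urea, though it starts from a different group. A smaller weakening is therefore expected for compound 4, estimated as a 2.0-fold higher number from compound 3 to compound 4 (0.30 log units; within the scatter) in this assay. Compound 4 is expected to give about 20000 nM, in the range 8000 nM to 60000 nM.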

Compound 4, half-maximal inhibitory concentration: 10300 nM
Compound 4: middle estimate off by 1.9-fold (0.29 log units), on the high side, and the stated range covers the measured number.
By their numbers in this assay, from the lowest: compounds 1, 3 and 4 (each within the scatter of the next); then compound 2.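

In this assay, fluoro in place of hydrogen on an aromatic carbon, ortho to a large group, leaves the number unchanged within the scatter, as a 1.0-fold higher number from compound 3 to compound 4 (0.01 log units; within the scatter) shows. Thus, on the core of compound 3, this position tolerates the change, which the earlier step, a 4.5-fold higher number from compound 1 to compound 2 (0.65 log units; beyond the scatter), could not show, since it replaced 4-(tert-butyl)phenyl rather than hydrogen. Nothing given here explains this result.

The compounds shown leave open whether chloro or methoxy at this position would move the number. They also leave open whether fluoro in place of hydrogen would be equally silent on the core of compound 2.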